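Lengthening the Acid Chain on Compound 2

The source may report more compounds than this note shows. Statements on the series, on what has been measured and on what is new or still open speak of the compounds shown alone.

Compound 2 `CCC(CC)(c1ccc(OCC(O)C(C)(C)C)c(C)c1)c1ccc(C(=O)NCC(=O)O)n1C` carries the highest number of the two measured compounds in an assay on HL-60 cells for agonist activity at vitamin D3 receptor (Homo sapiens), with a stated time of 96 h (on this read-out higher numbers stand for an effect only at larger amounts of compound and lower numbers for an effect already at smaller amounts), giving 4950 nM, while compound 1 `CCC(CC)(c1ccc(OCC(O)C(C)(C)C)c(C)c1)c1ccc(C(=O)NCCCO)n1C` gives 150 nM. The step of a 33-fold higher number from compound 1 to compound 2 (1.52 log units; beyond the scatter) shows how strongly the number rose when the carboxy group replaced the 2-hydroxyethyl group at this position. Compound 3 `CCC(CC)(c1ccc(OCC(O)C(C)(C)C)c(C)c1)c1ccc(C(=O)NCCC(=O)O)n1C` differs from compound 2 by carboxymethyl in place of carboxy on a saturated chain carbon bound to an amide-type nitrogen. For the measured compounds named here, no measured step covers extending this chain by one carbon, so the expected change is modest: the step of a 2.0-fold lower number from compound 2 to compound 3 (0.30 log units; within the scatter) is estimated. For compound 3 the expected value is 2500 nM, within a range of 700 nM to 9000 nM.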

Compound 3, half-maximal effective concentration: 1600 nM
For compound 3 the middle estimate is 1.6-fold (0.19 log units) above the measured one; the range from low to high includes it.
By their numbers in this assay, from the lowest: compound 1; then compound 3; then compound 2.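

In this assay, carboxymethyl in place of carboxy gives a 3.1-fold lower number from compound 2 to compound 3 (0.49 log units; beyond the scatter), so with the acid kept, the length of this chain still changes the number. Carboxy in place of hydroxymethyl on the same chain gives an 11-fold higher number from compound 1 to compound 3 (1.03 log units; beyond the scatter), so the longer acid closes only part of the gap to the alcohol. Nothing measured here explains either step. Still open, as far as these compounds go, is whether a longer acid chain, such as 3-carboxypropyl, would lower the number further. Also open, from the compounds shown here alone, is where an amine at the chain end would fall relative to the alcohol and the acids.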